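Swapping ethyl for 4-methoxycyclohexyl on an amide-type nitrogen

The compounds below may be only part of what the source reports. "The series", "measured", "known", "first", "only" and "open" are said of these compounds alone.

In a physicochemical assay for solubility (on this read-out lower numbers stand for lower solubility and higher numbers for higher solubility), compound 2 (`CCNC(=O)c1cc(C(=O)NC)nn1[C@@H](C)c1ccccc1`) gives >= 137 ug/mL, which is a limit of the assay and not a number. Compound 2 thus stands at the limit of >= 137 ug/mL in this assay, at which 1 of the 2 values shown sits. Compound 3 (`CNC(=O)c1cc(C(=O)N[C@H]2CC[C@H](OC)CC2)n([C@@H](C)c2ccccc2)n1`) carries 4-methoxycyclohexyl in place of ethyl on an amide-type nitrogen. Compound 1 (`CNC(=O)c1cc(C(=O)NC2CCOCC2)n([C@@H](C)c2ccccc2)n1`), which has oxan-4-yl at that place, gives 31 ug/mL in this assay. Among the compounds with values here, the one measured step that bears on this change is an at least 4.4-fold higher number from compound 1 to compound 2 (0.64 log units; beyond the scatter), with ethyl in place of oxan-4-yl, and it lies beyond the scatter. Compound 3 again has a six-membered ring there, so a change in the opposite direction is expected, towards the level of compound 1 at 31 ug/mL. The expected step is an at least 6.8-fold lower number from compound 2 to compound 3 (0.83 log units; beyond the scatter), to a lower number and beyond the scatter. For compound 3 the estimated value is 20 ug/mL, with an expected range from 6 ug/mL to 70 ug/mL.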

Compound 3, solubility: >= 161 ug/mL
Compound 3 ended at the assay's limit; the forecaster's own chance of this, stated with the estimate: 5%; middle value at least 8.0-fold (0.90 log units) from the limit.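

In this assay compound 3 ends at a limit of the assay and not at a number: the limit of >= 161 ug/mL in this assay, at which 1 of the 3 values shown sits. Compound 1 and compound 3 both carry a six-membered ring on the amide-type nitrogen, yet 4-methoxycyclohexyl in place of oxan-4-yl gives an at least 5.1-fold higher number from compound 1 to compound 3 (0.71 log units; beyond the scatter), so having a ring at this place does not in itself fix the read-out at a low level. The step between compound 2 and compound 3 cannot be read, as both values are limits.

Going by these compounds, how far compound 2 and compound 3 lie apart therefore stays open, as does how high either of them really reaches. Also open, on these data alone, is what a piperidin-4-yl amine or a longer chain such as butyl would give on this nitrogen.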